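The source may report more compounds than this note shows. Statements on the series, on what has been measured and on what is new or still open speak of the compounds shown alone.

In an ADME assay on the whole organism (strain FVB) for pharmacokinetics, with Mus musculus as the target, read by LC-MS, at a dose of 30 mg/kg by the oral route (on this read-out lower numbers stand for lower exposure and higher numbers for higher exposure at the dose given), compound 1 (`c1cc([C@H]2CC[C@]3(CC2)OOC2(O3)C3CC4CC(C3)CC2C4)ccc1OCCOC1CCNCC1`) gives 9180 ng.h/mL, compound 2 (`c1cc([C@H]2CC[C@]3(CC2)OOC2(O3)C3CC4CC(C3)CC2C4)ccc1OCCC1CCNCC1`) gives 16000 ng.h/mL and compound 3 (`CC(C)(CN)Oc1ccc([C@H]2CC[C@]3(CC2)OOC2(O3)C3CC4CC(C3)CC2C4)cc1`) gives 4840 ng.h/mL. Two steps place compound 3: a 1.9-fold lower number from compound 1 to compound 3 (0.28 log units; within the scatter), and a 3.3-fold lower number from compound 2 to compound 3 (0.52 log units; beyond the scatter). Compound 4 (`NCCCCOc1ccc([C@H]2CC[C@]3(CC2)OOC2(O3)C3CC4CC(C3)CC2C4)cc1`) has the same atoms as compound 3, joined differently: 4-aminobutyl in place of 1-(aminomethyl)-1-methylethyl on an oxygen on an aromatic ring. Within the data shown here, no measured step makes this exact exchange. The two steps above replaced the whole group on that oxygen and moved the number modestly at most, while a 1.7-fold higher number from compound 1 to compound 2 (0.24 log units; within the scatter) altered only the chain. No step beyond the scatter is therefore expected, and the expected step is a 1.2-fold higher number from compound 3 to compound 4 (0.09 log units; within the scatter). Compound 4 is estimated at 6000 ng.h/mL, with an expected range of 2500 ng.h/mL to 14000 ng.h/mL.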

Compound 4, area under the concentration-time curve: 4700 ng.h/mL
Compound 4: the middle estimate sits 1.3-fold (0.11 log units) above what was measured; low and high end bracket the measured number.
By their numbers in this assay, from the lowest: compounds 4, 3, 1 and 2 (each within the scatter of the next, the first and the last beyond it).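

In this assay, the same atoms arranged as 4-aminobutyl rather than 1-(aminomethyl)-1-methylethyl on this oxygen on an aromatic ring read alike (a 1.0-fold lower number from compound 3 to compound 4 (0.01 log units; within the scatter)), so branching in this group made no difference that the assay could resolve here. The 2-aminoethyl chain end of compound 4 separates from the piperidin-4-yl end (a 3.4-fold lower number from compound 2 to compound 4 (0.53 log units; beyond the scatter)) but not from the (piperidin-4-yl)oxy end (a 2.0-fold lower number from compound 1 to compound 4 (0.29 log units; within the scatter)). No evidence here bears on the reason for these numbers.

On these data alone, whether a longer chain ending in an amine, a dimethylamino end or a carboxylic acid at the same place would change the exposure stays open.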